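This account rests on a few compounds, and the source may have more. Where it says the series, first, only, none or still open, it means among the compounds named here.

Compound 1, with the structure `O=C(c1ccc(NCc2cncn2Cc2ccc(-c3ccccc3)cc2)cc1-c1ccccc1)N1CCCCC1`, was tested in a toxicity assay on NIH3T3 cells (Mus musculus) for cytotoxicity, read by resazurin assay; on this read-out higher numbers stand for an effect only at larger amounts of compound and lower numbers for an effect already at smaller amounts. For compound 1 the result is > 1000 nM, which is a limit of the assay and not a number; this is the limit of > 1000 nM in this assay, at which 2 of the 3 values shown sit. Compound 2, `COC(=O)c1ccc(NCc2cncn2Cc2ccc([N+](=O)[O-])cc2)cc1-c1ccccc1`, gives in this assay > 10000 nM, again a limit of the assay, namely (the limit of > 10000 nM in this assay, at which 1 of the 3 values shown sits). Compound 3, `Cc1ccccc1-c1cccc(NCc2cncn2Cc2ccccc2)c1`, also stops in this assay at the limit > 1000 nM. Compound 4, `c1ccc(-c2ccc(Cn3cncc3CNc3ccc(N4CCCCC4)c(-c4ccccc4)c3)cc2)cc1`, differs from compound 1 in one place: piperidin-1-yl in place of (piperidin-1-yl)carbonyl on an aromatic carbon. Within the data shown here, no step between measured compounds is known, so the change is expected to leave this assay unchanged beyond the scatter, with the step that the limit leaves unreadable from compound 1 to compound 4 expected to be small and in no clear direction. Compound 4 is therefore expected to give about 3000 nM in this assay, between 1000 nM and 20000 nM.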

Compound 4, half-maximal effective concentration: > 1000 nM
Compound 4 was reported as a limit; the forecaster's own chance of this, stated with the estimate: 80%; the middle value lies beyond the limit too.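

Among these compounds, compound 1 and compound 4 both end at a limit in this assay; no step between them can be read. The compounds shown leave open whether piperidin-1-yl in place of (piperidin-1-yl)carbonyl changes the amount at which an effect appears.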